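Inserting an oxygen into the benzyl link

This account rests on a few compounds, and the source may have more. Where it says the series, first, only, none or still open, it means among the compounds named here.

Measured so far:
compound 1 `CCS(=O)(=O)N(Cc1cccnc1)c1cccc(C(O)c2ccccc2)c1` — 2500 nM
compound 2 `CCS(=O)(=O)N(Cc1cccnc1)c1cccc(C(=O)c2ccccc2)c1` — 1100 nM
compound 3 `CCS(=O)(=O)N(Cc1cccnc1)c1cccc(Cc2ccccc2)c1` — 310 nM

In an assay on isolated protein with metabotropic glutamate receptor 2 (Homo sapiens) as the target (on this read-out higher numbers stand for an effect only at larger amounts of compound and lower numbers for an effect already at smaller amounts), compound 3 gives 310 nM, the lowest number of the three, while compound 2 gives 1100 nM and compound 1 gives 2500 nM. The three compounds share one core and differ only in the group attached to it: hydroxy(phenyl)methyl in compound 1, benzoyl in compound 2 and benzyl in compound 3. Each change toward the plain benzyl lowered the number: a 2.3-fold lower number from compound 1 to compound 2 (0.36 log units; beyond the scatter), a 3.5-fold lower number from compound 2 to compound 3 (0.55 log units; beyond the scatter) and an 8.1-fold lower number from compound 1 to compound 3 (0.91 log units; beyond the scatter).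

Compound 4 `CCS(=O)(=O)N(Cc1cccnc1)c1cccc(COc2ccccc2)c1` is not yet measured. It differs from compound 3 by phenoxy in place of phenyl on a saturated chain carbon bound to an aromatic carbon. As in the steps toward compound 1 and compound 2, an oxygen enters near the link between the core and the phenyl, and in those steps every added oxygen went with a higher number. Within the data shown here, no measured pair contains an oxygen placed in the chain itself, so the size is uncertain, but the direction in this assay is expected to be upward by a modest amount. Compound 4 is therefore expected to give about 900 nM, within a range from 300 nM to 3000 nM. This estimate corresponds to an expected step of a 2.9-fold higher number from compound 3 to compound 4 (0.46 log units; beyond the scatter).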

Compound 4, half-maximal effective concentration: 160 nM
Estimate against measurement, compound 4: 5.6-fold (0.75 log units) above, and the stated range ends above it.
By their numbers in this assay, from the lowest: compounds 4 and 3 (each within the scatter of the next); then compound 2; then compound 1.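

In this assay, moving the oxygen into the chain gives a 1.9-fold lower number from compound 3 to compound 4 (0.29 log units; within the scatter), so the phenoxymethyl group and the benzyl group cannot be told apart at this position. The same chain oxygen sets compound 4 clearly apart from the two compounds that carry their oxygen on the carbon bound to the core, with a 6.9-fold lower number from compound 2 to compound 4 (0.84 log units; beyond the scatter) and a 16-fold lower number from compound 1 to compound 4 (1.19 log units; beyond the scatter). Compound 4 thus goes against the pattern of compounds 1 and 2, showing that an added oxygen does not always come with a higher number here and that its placement matters; why it matters finds no answer in the information available.

Going by these compounds, it remains open whether other atoms can fill the same place in the chain, as a nitrogen would in a phenylaminomethyl group or a sulfur in a phenylthiomethyl group. On these data alone, it is also open whether a longer chain, such as phenoxyethyl, or a fluorine on the phenyl ring of the phenoxy group, would keep the number as low as in compound 3 and compound 4.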